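The source may hold more compounds than are shown below. What is called first, only, known or untested is meant among the compounds shown, and "the series" means these compounds.

Compound 2 `O=C(NCCCCC(c1ccc(F)cc1)c1ccc(F)cc1)Nc1ccc(Cl)c(C(F)(F)F)c1` gives 90% in an ADME assay on isolated protein for inhibition of sodium-dependent dopamine transporter (Homo sapiens), tested at 10 uM (a lower number here means less inhibition, a higher number more inhibition at the concentration tested (going by the name of the read-out)), the highest of the three measured compounds. Compound 3 `Cc1ccc(NC(=O)NCCCCC(c2ccc(F)cc2)c2ccc(F)cc2)cc1C` gives 79%, and compound 1 `O=C(NCCCCC(c1ccc(F)cc1)c1ccc(F)cc1)Nc1ccc(I)cc1` gives 24%. Compound 4 `Cc1cc(Cl)ccc1NC(=O)NCCCCC(c1ccc(F)cc1)c1ccc(F)cc1` has not yet been measured; it differs from compound 2 by 4-chloro-2-methylphenyl in place of 4-chloro-3-(trifluoromethyl)phenyl on an amide-type nitrogen. Among the measured compounds shown here, two measured steps bear on this change of the aryl group on the amide-type nitrogen: a number 11 percentage points lower from compound 2 to compound 3 (beyond the scatter) and a number 66 percentage points higher from compound 1 to compound 2 (beyond the scatter). Exchanging the aryl group can therefore move the read-out a great deal, and the single chlorine and methyl of compound 4 resemble the dimethylphenyl of compound 3 more than the iodophenyl of compound 1. He therefore expects a modest fall, a number 18 percentage points lower from compound 2 to compound 4 (beyond the scatter), and estimates compound 4 at 72%, between 45% and 90%.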

Compound 4, a percentage reported as inhibition, at one concentration (the size of the read-out at that concentration, not a potency): 58%
The estimate for compound 4 lay 14 percentage points above the measured number; low and high end bracket the measured number.
By their numbers in this assay, from the lowest: compound 1; then compound 4; then compound 3; then compound 2.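

In this assay, keeping the chlorine of compound 2 does not keep the read-out high: the change to 4-chloro-2-methylphenyl gives a number 32 percentage points lower from compound 2 to compound 4 (beyond the scatter) and, against the dimethylphenyl, a number 21 percentage points lower from compound 3 to compound 4 (beyond the scatter). The same group still gives a number 34 percentage points higher from compound 1 to compound 4 (beyond the scatter), so this aryl position on the amide-type nitrogen yields an intermediate result as well as the extremes seen earlier. No measurement here accounts for these differences. The compounds shown leave open whether the fall belongs to the added methyl or to the lost trifluoromethyl, and how an aryl group carrying an amine or a carboxylic acid would read.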